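Glucagon receptor series: a 2-methylphenyl variant of compound 2

The source may hold more compounds than are shown below. What is called first, only, known or untested is meant among the compounds shown, and "the series" means these compounds.

Measured compounds:
- compound 1 `CCC/C=C/c1c(C(C)C)nc(C(C)C)c(CO)c1-c1ccc(S(C)(=O)=O)cc1`: 14%
- compound 2 `CCCCCc1c(C(C)C)nc(C(C)C)c(CO)c1-c1ccc(O)cc1`: 24%
- compound 3 `CCCCCc1c(C(C)C)nc(C(C)C)c(CO)c1-c1ccc2c(c1)CCCC2`: 37%

In an assay on CHO cells for inhibition of Glucagon receptor (Homo sapiens), tested at 20 uM (on this read-out lower numbers stand for less inhibition and higher numbers for more inhibition at the one concentration tested (going by the name of the read-out)), compound 2 gives 24%. Compound 1 gives 14% in this assay, which lies within the usual scatter of the number for compound 2, so nothing separates the two. Compound 3 gives 37% in this assay, a number beyond the scatter and higher than that of compound 2. Among the three, compound 2 thus sits between a value it cannot be told apart from and one clearly above it.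

Compound 4 `CCCCCc1c(C(C)C)nc(C(C)C)c(CO)c1-c1ccccc1C` is not yet measured. It differs from compound 2 in one place: 2-methylphenyl in place of 4-hydroxyphenyl on an aromatic carbon. Among the measured compounds shown here, no measured pair in the set shares this change, so its effect on this assay is unknown. For the measured compounds named here, with the spread of the three measured numbers as the only guide, the step is expected to be small, in either direction or none beyond the scatter: a number 3 percentage points higher from compound 2 to compound 4 (within the scatter). Compound 4 is expected to give about 27% in this assay, between 5% and 50%.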

Compound 4, a percentage reported as inhibition, at one concentration (the size of the read-out at that concentration, not a potency): 33%
Compound 4: middle estimate off by 6 percentage points, on the low side; measured number inside the range.
By their numbers in this assay, from the lowest: compounds 1, 2, 4 and 3 (each within the scatter of the next, the first and the last beyond it).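

In this assay, 2-methylphenyl in place of 4-hydroxyphenyl, on the aromatic carbon opposite the ring nitrogen, gives a number 9 percentage points higher from compound 2 to compound 4 (within the scatter), the first one-place comparison available in this set. At this position, the hydroxyl group, with its hydrogen-bond donor and acceptor, can therefore be exchanged for a methyl-bearing phenyl without a step beyond the scatter, although this rests on one pair only. Nothing at hand gives a reason for this outcome.

The compounds shown leave open whether an amine or a carboxylic acid on the phenyl group at this position would move the number in this assay beyond the scatter. They also leave open whether a longer chain in place of the pentyl group would shift the number for the 2-methylphenyl compound.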